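Capping the Terminal Amine of Compound 1

The source may report more compounds than this note shows. Statements on the series, on what has been measured and on what is new or still open speak of the compounds shown alone.

Compound 1 `Cn1c(=O)c(C(=O)NCCCCCCN)c(O)c2ccccc21` is the starting point. Going by the values given here, in a functional assay, with a stated time of 20 min, tested at 0.5 mM (a higher number here means a stronger effect of the compound at the concentration tested, a lower number a weaker effect), compound 1 gives 13.7%, the lowest of the three numbers measured so far. Compound 2 `NCCCCCCNC(=O)c1c(O)c2ccccc2n(-c2ccccc2)c1=O` gives 19.3%, and compound 3 `Cn1c(=O)c(C(=O)Nc2ccccc2N)c(O)c2ccccc21` gives 28.8%. The step of a number 5.6 percentage points higher from compound 1 to compound 2 (within the scatter) comes from phenyl in place of methyl on an aromatic nitrogen, while the step of a number 15.1 percentage points higher from compound 1 to compound 3 (beyond the scatter) comes from 2-aminophenyl in place of 6-aminohexyl on an amide-type nitrogen.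

Compound 4 `Cn1c(=O)c(C(=O)NCCCCCCNC(=O)CCCCC2CCSS2)c(O)c2ccccc21` keeps the whole of compound 1 and differs at one spot: a group of 11 heavy atoms (8 carbon, 1 oxygen, 2 sulfur; one five-membered non-aromatic ring with 2 hetero atoms) in place of a hydrogen atom, on an amine nitrogen. Neither measured step touches this place: one alters the aromatic nitrogen, the other replaces the 6-aminohexyl chain altogether. Among the compounds with values here, there is thus no direct guide for this change; the only step beyond the scatter so far swapped the chain out rather than building onto its end. The expected step of a number 2.3 percentage points higher from compound 1 to compound 4 (within the scatter) is therefore small, with no direction favoured beyond the scatter. Compound 4 is estimated to give 16% in this assay, expected to fall between 5% and 30%.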

Compound 4, a percentage reported as activity, at one concentration (the size of the read-out at that concentration, not a potency): 28.4%
For compound 4 the middle estimate is 12.4 percentage points below the measured one; the measured number falls inside the stated range.
By their numbers in this assay, from the lowest: compounds 1, 2, 4 and 3 (each within the scatter of the next, the first and the last beyond it).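

In this assay the step of a number 14.7 percentage points higher from compound 1 to compound 4 (beyond the scatter) shows that the amine nitrogen at the end of the 6-aminohexyl chain is a place where a change can move the read-out beyond the scatter. Going by these compounds alone, until now, the only step of that size replaced the whole chain, whereas here the chain stays and the new group, with its five-membered non-aromatic ring holding 2 sulfur atoms, is built onto its end. Nothing available explains why this group gives a higher number.

From the compounds shown here alone, it remains open whether the ring matters or whether capping the amine nitrogen is enough, a question that a simple acetyl group on the same nitrogen could address. Also open, going by these compounds, is how a shorter or longer chain carrying the same group would compare with compound 4 in this read-out.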